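Chloro in place of methoxy in compound 1

The source may hold more compounds than are shown below. What is called first, only, known or untested is meant among the compounds shown, and "the series" means these compounds.

In a functional assay on MDA-MB-468 cells (Homo sapiens) for antiproliferative activity, read by sulforhodamine B assay, with a stated time of 48 h (on this read-out lower numbers stand for stronger inhibition and higher numbers for weaker inhibition), compound 1 `COc1ccc(-c2nsc3c2NC(=O)CC3c2cccc(OC)c2)cc1` gives 395 nM and compound 2 `COc1ccc(-c2nsc3c2NC(=O)CC3c2ccc3c(c2)OCCO3)cc1` gives 328 nM on the same read-out. Within the data shown here, these two numbers lie within the usual scatter of each other, so compound 1 cannot be ranked against compound 2, and the series so far offers no measured spread to work from.

Compound 3 `COc1ccc(-c2nsc3c2NC(=O)CC3c2cccc(Cl)c2)cc1` keeps the core of compound 1 and carries chloro in place of methoxy on an aromatic carbon, meta to a large group (chloro in place of methoxy on an aromatic carbon). The 3-methoxyphenyl thus becomes 3-chlorophenyl. Among the measured compounds shown here, no measured pair shows this replacement or any other single change, so the expectation has little support and the range is kept wide.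

In this assay no change beyond the scatter is expected, and neither direction is favoured. The estimated step of a 1.0-fold lower number from compound 1 to compound 3 (0.02 log units; within the scatter) is expected to stay within the scatter. Compound 3 is estimated at 380 nM with an expected range (150 nM to 950 nM).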

Compound 3, half-maximal inhibitory concentration: 174 nM
Beside the measured number, compound 3's estimate is 2.2-fold (0.34 log units) above it, and the stated range covers the measured number.
By their numbers in this assay, from the lowest: compounds 3, 2 and 1 (each within the scatter of the next, the first and the last beyond it).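

Among these compounds, replacing methoxy with chloro on the aromatic carbon, meta to a large group, gives in this assay a 2.3-fold lower number from compound 1 to compound 3 (0.36 log units; beyond the scatter) and provides the first single-place comparison, as well as its first step beyond the scatter. The earlier pair could not be ranked, whereas this pair shows that the number at this position responds to the group it carries, although the step is modest and rests on one pair alone. It also shows that, with the core of compound 1 held constant, the 3-methoxyphenyl group is not required for activity on this read-out, and no measured evidence here bears on the reason for the step.

Still open, going by these compounds, is how the number would respond on the same aromatic carbon to fluoro, bromo, trifluoromethyl, an amine or a carboxylic acid, and thus whether chloro is a particular gain or one point on a broader trend. Also open is whether the same replacement gives a step of similar size when the methoxy on the other aromatic group of the shared core is changed, since that group is identical in all the compounds shown.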